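Compound 3: replacing the 1,2-dihydroxyethyl group

The source may hold more compounds than are shown below. What is called first, only, known or untested is meant among the compounds shown, and "the series" means these compounds.

In a physicochemical assay for lipophilicity, read by HPLC, measured as chromatographic lipophilicity (a lower number here means a more polar compound, a higher number a more lipophilic compound), compound 2 (`CCC/N=C1\S/C(=C\c2ccc(C(=O)OCC(O)CO)cc2)C(=O)N1c1ccccc1O`) stands lowest at 1.8, and compound 1 (`CCC/N=C1\S/C(=C\c2ccc(C(=O)OCCCO)cc2)C(=O)N1c1ccccc1O`) gives 2.3. Compound 3 (`CCC/N=C1\S/C(=C\c2ccc(C(=O)OCc3oc(=O)oc3C)cc2)C(=O)N1c1ccccc1O`) differs from compound 2 by a group of 7 heavy atoms (4 carbon, 3 oxygen; one five-membered aromatic ring with 2 hetero atoms) in place of a group of 4 heavy atoms (2 carbon, 2 oxygen; no ring), on a saturated chain carbon bound to an oxygen next to a carbonyl group. Within the data shown here, only one measured step bears on this: a number 0.50 log units lower from compound 1 to compound 2 (beyond the scatter), modest and downward, with hydroxy in place of hydrogen. Among the measured compounds shown here, the new change removes the hydroxy groups of the 1,2-dihydroxyethyl, so the direction is expected to reverse, although no measured compound carries the entering ring. In this assay a larger, upward step is expected, estimated as a number 1.20 log units higher from compound 2 to compound 3 (beyond the scatter). Compound 3 is estimated at 3, with a range of 2.5 to 3.5.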

Compound 3, distribution coefficient: 3.3
The estimate for compound 3 lay 0.30 log units below the measured number; measured number inside the range.
By their numbers in this assay, from the lowest: compound 2; then compound 1; then compound 3.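

At this place, on a saturated chain carbon bound to an oxygen next to a carbonyl group, the number in this assay can also rise: a number 1.50 log units higher from compound 2 to compound 3 (beyond the scatter) and a number 1.00 log units higher from compound 1 to compound 3 (beyond the scatter) with the five-membered aromatic ring group in place. Compound 3 therefore stands highest of the three. Nothing available accounts for the size of these steps.

The compounds shown do not separate the effect of the entering ring from that of losing the hydroxy groups. From the compounds shown here alone, how a longer plain alkyl chain, an amine or a carboxylic acid at this place would read in this assay remains open.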